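Amine swap carried from one core onto another

The compounds below may be only part of what the source reports. "The series", "measured", "known", "first", "only" and "open" are said of these compounds alone.

In an assay on nucleic acid for inhibition of Nucleic Acid, read by fluorescence, tested at 100 uM (a higher number here means more inhibition at the concentration tested (going by the name of the read-out), a lower number less inhibition), compound 1 `CCCCN(CCCC)Cc1cn(CC(O)COC(=O)NCc2ccccc2)nn1` gives 42%. Compound 2 `CC(C)CCN(C)Cc1cn(CC(O)COC(=O)NCc2ccccc2)nn1` carries the change (isopentyl(methyl)amino in place of dibutylamino on a saturated chain carbon bound to an aromatic carbon); in this assay compound 2 gives 26%. For the measured compounds named here, the step, a number 16 percentage points lower from compound 1 to compound 2 (beyond the scatter), is the only measured instance of this change so far. Compound 3 `CCCCN(CCCC)Cc1cn(C2CCCCC2OC(=O)COc2ccccc2)nn1` has a different core; the difference between the cores of compound 1 and compound 3 is not broken down here. In this assay compound 3 gives 26%, level with compound 2 at the digits printed, and the two together are the lowest of the three numbers, with compound 1 standing higher.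

Compound 4 `CC(C)CCN(C)Cc1cn(C2CCCCC2OC(=O)COc2ccccc2)nn1` has not been measured. It differs from compound 3 by isopentyl(methyl)amino in place of dibutylamino on a saturated chain carbon bound to an aromatic carbon, the same change that separates compound 1 from compound 2; among the compounds shown this change occurs twice. The expected step in this assay, a number 12 percentage points lower from compound 3 to compound 4 (beyond the scatter), is set beside the measured a number 16 percentage points lower from compound 1 to compound 2 (beyond the scatter). It rests on that single earlier step and on compound 3 starting from 26%, which already sits at the lower of the two levels seen, so a step of the full earlier size would leave little inhibition at the concentration tested; a somewhat smaller drop is expected. Compound 4 is estimated at 14%, with a range from 2% to 30%.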

Compound 4, a percentage reported as inhibition, at one concentration (the size of the read-out at that concentration, not a potency): 59%
The estimate for compound 4 lay 45 percentage points below the measured number; measured number above the stated range.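

In this assay, the swap of dibutylamino for isopentyl(methyl)amino, carried onto the other core, gives a number 33 percentage points higher from compound 3 to compound 4 (beyond the scatter), so the direction seen on the first core does not hold on the second. The two instances of the same change disagree in both direction and size: the same change on two cores in this assay, a number 16 percentage points lower (beyond the scatter) from compound 1 to compound 2 and a number 33 percentage points higher (beyond the scatter) from compound 3 to compound 4, 49 percentage points apart, beyond the scatter of two such steps This shows that in this series the outcome of the swap depends on the core that carries it, so a step measured on one core is a poor guide to the step on the other, although it does not show which part of the cores decides the outcome, and two instances give no rule for any further core or any potency, each step resting on percentages read at a single concentration.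

The compounds shown leave open which of the several differences between the two cores accounts for the reversal, since those differences are not separated here. They also leave open how other amines behave on each core, for example dimethylamino or dipentylamino in the same place, and so whether the two cores keep their opposite trends beyond this one pair of amines.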